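A few compounds are considered here, and "the series" means these few. Any claim that something is new, unique, unknown or untested is made for them only; others in the source may bear on it.

Series notes. Compound 1 `CC(NC(=O)COc1cc(C(F)(F)F)c2c(-c3ccccc3)nn(C)c2n1)c1ccccn1` and compound 2 `CC(NC(=O)COc1cc(C(F)(F)F)c2c(-c3ccccc3)nn(C)c2n1)c1cccnc1` share the whole core and differ only in the ring on the chain carbon bound to the amide nitrogen. In a functional assay on isolated protein for antagonist activity at Orexin/Hypocretin receptor type 1 (Homo sapiens), read by fluorescence, FLIPR and calcium flux, with a stated time of 1 h (a higher number here means a weaker inhibitor, a lower number a stronger inhibitor), compound 1 gives 2670 nM, and compound 2 gives 970 nM; the step of a 2.8-fold lower number from compound 1 to compound 2 (0.44 log units; beyond the scatter) is the only measured one so far. Compound 2 thus stands at the lower of the two numbers, with compound 1 the nearer and only neighbour.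

Compound 3 `Cc1nn(C)c(C)c1[C@H](C)NC(=O)COc1cc(C(F)(F)F)c2c(-c3ccccc3)nn(C)c2n1` carries the change (1-(1,3,5-trimethyl-1H-pyrazol-4-yl)ethyl in place of 1-(pyridin-3-yl)ethyl on an amide-type nitrogen). Among the compounds with values here, no measured step bears directly on this swap: the single measured step concerns two pyridine isomers, not a pyridole-for-pyridine exchange, so its size cannot be transferred. The expectation for compound 3 is therefore a step of a 1.2-fold lower number from compound 2 to compound 3 (0.08 log units; within the scatter) of no clear direction, kept close to compound 2 with a wide band. Compound 3 is expected to give 800 nM in this assay, estimated between 200 nM and 3000 nM.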

Compound 3, inhibition constant: 7 nM
Beside the measured number, compound 3's estimate is 110-fold (2.06 log units) above it; the whole stated range lies above it.
By their numbers in this assay, from the lowest: compound 3; then compound 2; then compound 1.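

Notes on the position. At the amide-type nitrogen, the group carried there can move the number in this assay far more than the pyridine isomers suggested: the step is a 140-fold lower number from compound 2 to compound 3 (2.14 log units; beyond the scatter) and a 380-fold lower number from compound 1 to compound 3 (2.58 log units; beyond the scatter), against only a 2.8-fold lower number from compound 1 to compound 2 (0.44 log units; beyond the scatter) between the two pyridines. The 1-(1,3,5-trimethyl-1H-pyrazol-4-yl)ethyl group differs from both 1-(pyridinyl)ethyl groups in ring size, hetero atoms and methyl groups, and it also brings one defined stereocentre, so these steps read as a single bundled change that cannot be divided among those features. Nothing available here accounts for the size of these steps.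

As far as these compounds go, the opposite stereocentre of compound 3 remains open. So does whether a 1-(1H-pyrazol-4-yl)ethyl group, lacking all three methyl groups, would keep the number near that of compound 3.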